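Configuration at a saturated ring carbon: outlook for compound 3

A few compounds are considered here, and "the series" means these few. Any claim that something is new, unique, unknown or untested is made for them only; others in the source may bear on it.

Within the data shown here, in an in vivo ADME assay on the whole organism (strain Sprague-Dawley) for pharmacokinetics, with Rattus norvegicus as the target (a lower number here means that a smaller share of the oral dose reaches the circulation, a higher number that a larger share of the oral dose reaches the circulation), compound 1 `O=C1[C@@H](NS(=O)(=O)c2ccc3cc(Cl)ccc3c2)CCN1c1ccc(C2CCCN2)cc1F` gives 24% and compound 2 `O=C1[C@@H](NS(=O)(=O)c2ccc3cc(Cl)ccc3c2)CCN1c1ccc([C@H]2CCCN2)cc1F` gives 25% so compound 2 stands level with the only other measured compound. Among the measured compounds shown here, the one step bearing on the change, a number 1 percentage points higher from compound 1 to compound 2 (within the scatter), compares a defined configuration with an undefined one the fact that one of compounds 1 and 2 is drawn with a defined configuration and the other without, at the place where they differ and stays within the scatter. Compound 3 `O=C1[C@@H](NS(=O)(=O)c2ccc3cc(Cl)ccc3c2)CCN1c1ccc([C@@H]2CCCN2)cc1F` differs from compound 2 as follows: the two compounds have the same atoms and bonds and differ only in configuration as drawn: 1 of 2 stereo elements differ; a stereocentre at a saturated ring carbon is drawn R in compound 2 and S in compound 3. For the measured compounds named here, no measured compound is drawn with this configuration, so the range stays wide. The expected change is a number 2 percentage points lower from compound 2 to compound 3 (within the scatter) in this assay, with no step beyond the scatter in either direction. Compound 3 is expected at 23% within an estimated range of 12% to 36% for now.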

Compound 3, oral bioavailability: 38%
Beside the measured number, compound 3's estimate is 15 percentage points below it, outside the stated range (above it).
By their numbers in this assay, from the lowest: compounds 1 and 2 (each within the scatter of the next); then compound 3.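

In this assay, the configuration at this saturated ring carbon now makes a difference beyond the scatter, with S ahead of R: a number 13 percentage points higher from compound 2 to compound 3 (beyond the scatter). Against the form drawn without a configuration, the picture is the same: a number 14 percentage points higher from compound 1 to compound 3 (beyond the scatter). The step can be assigned to this stereocentre alone because nothing else separates the pair: the fact that compounds 2 and 3 differ only in the configuration as drawn

The compounds shown do not tell why the S configuration gives the higher oral bioavailability. Going by these compounds, it also remains open whether this preference would persist with a methyl group or a carboxylic acid at this saturated ring carbon.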